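Sulfonamide methylation on the fused core

This account rests on a few compounds, and the source may have more. Where it says the series, first, only, none or still open, it means among the compounds named here.

Measured compounds:
compound 1 `CCS(=O)(=O)Nc1cccc2c1CCCC2c1c[nH]cn1` gives 6.77
compound 2 `CCS(=O)(=O)Nc1cccc(Cc2c[nH]cn2)c1C` gives 5.6

Going by the values given here, in a functional assay on Urethra for agonist activity at Alpha-1A adrenergic receptor (Oryctolagus cuniculus) (a higher number here means a more potent compound, by a factor of ten per unit of this negative logarithm, a lower number a less potent compound), compound 1 gives 6.77, the higher of the two numbers so far; in the same assay compound 2 gives 5.6, a reading beyond the usual scatter below that of compound 1. Among the compounds with values here, the two structures differ in more than one place, so no single step can be drawn between them; the values only show that the fused core of compound 1 carries the stronger response here.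

Compound 3 `CN(c1cccc2c1CCCC2c1c[nH]cn1)S(C)(=O)=O` has not yet been measured. Compared with compound 1 the difference is methyl(methylsulfonyl)amino in place of (ethylsulfonyl)amino on an aromatic carbon. The change removes the hydrogen-bond donor while keeping the same atom count. Within the data shown here, no measured pair isolates this change, so the expectation rests on compound 1 alone. The step from compound 1 to compound 3 is expected to be a modest loss, a number 0.57 log units lower from compound 1 to compound 3 (beyond the scatter), with a wide range. Compound 3 is estimated at 6.2, between 5.4 and 7.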

Compound 3, negative logarithm of the half-maximal effective concentration: 6.16
Compound 3: the middle estimate sits 0.04 log units above what was measured, within the range that was stated.
By their numbers in this assay, from the lowest: compound 2; then compound 3; then compound 1.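

In this assay, going by these compounds alone, a number 0.61 log units lower from compound 1 to compound 3 (beyond the scatter), which gives the first reading of a change at this aromatic carbon of the shared core. With methyl(methylsulfonyl)amino, which carries no hydrogen-bond donor, compound 3 still gives 6.16, so agonist activity here does not depend on the sulfonamide hydrogen, although the number is lower. The change replaces that hydrogen with methyl and also ethyl on the sulfur with methyl, so the step cannot be divided between the two, and nothing at hand explains the loss.

Still open, as far as these compounds go, are the two single changes: (methylsulfonyl)amino, which keeps the hydrogen, and methyl(ethylsulfonyl)amino, which keeps the ethyl. Also open, from the compounds shown here alone, is how a longer chain on the sulfur, such as propyl, or an acetylamino group in place of the sulfonamide would read on this core.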